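The compounds below may be only part of what the source reports. "The series", "measured", "known", "first", "only" and "open" are said of these compounds alone.

Working notes on the series, activity in a functional assay on HCT-116 cells (Homo sapiens) for inhibition; a higher number here means a weaker inhibitor, a lower number a stronger inhibitor.

Compound 1 `CCNC(=O)c1noc(-c2cc(C(C)C)c(O)cc2O)c1-c1cc(CN)no1` gives 84 nM in this assay. Compound 2 `CCCNCc1cc(-c2c(C(=O)NCC)noc2-c2cc(C(C)C)c(O)cc2O)on1` gives 117 nM, and compound 3 `CCNC(=O)c1cc(-c2c(C(=O)NCC)noc2-c2cc(C(C)C)c(O)cc2O)on1` gives 14 nM. Compound 1 stands second highest of the three numbers: its nearest neighbour is compound 2, with a 1.4-fold higher number from compound 1 to compound 2 (0.14 log units; within the scatter), and its furthest is compound 3, with a 6.0-fold lower number from compound 1 to compound 3 (0.78 log units; beyond the scatter). Between the other two the step is an 8.4-fold lower number from compound 2 to compound 3 (0.92 log units; beyond the scatter).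

Compound 4 `CCNC(=O)c1noc(-c2cc(C(C)C)c(O)cc2O)c1-c1ccn(C)n1` is not yet measured. Compared with compound 1 the change is 1-methyl-1H-pyrazol-3-yl in place of 3-(aminomethyl)-1,2-oxazol-5-yl on an aromatic carbon.

The measured steps bear on this only indirectly. The step from compound 1 to compound 2 shows that a propyl on the amine nitrogen leaves the number within the scatter. The steps to compound 3 show that exchanging the aminomethyl for an ethylcarbamoyl on the aromatic carbon gives a modest gain. Among the compounds with values here, compound 4 carries neither group, and the whole five-membered ring is exchanged, so no measured step matches the change. The hydrogen-bond donor of the aminomethyl is lost, as is one acceptor. No step beyond the scatter is expected in either direction; the estimated step is a 1.1-fold higher number from compound 1 to compound 4 (0.03 log units; within the scatter). Compound 4 is accordingly expected to give about 90 nM, within 35 nM to 250 nM.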

Compound 4, half-maximal inhibitory concentration: 16 nM
For compound 4 the middle estimate is 5.6-fold (0.75 log units) above the measured one; the whole stated range lies above it.
By their numbers in this assay, from the lowest: compounds 3 and 4 (each within the scatter of the next); then compounds 1 and 2 (each within the scatter of the next).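

At this position, on an aromatic carbon of a five-membered aromatic ring with 1 nitrogen and 1 oxygen, the whole 3-(aminomethyl)-1,2-oxazol-5-yl group can be exchanged with a gain in this assay: 1-methyl-1H-pyrazol-3-yl gives a 5.3-fold lower number from compound 1 to compound 4 (0.72 log units; beyond the scatter), and against the propylated amine it gives a 7.3-fold lower number from compound 2 to compound 4 (0.86 log units; beyond the scatter). The ethylcarbamoyl is therefore not the only route to the lower numbers, since a 1.1-fold higher number from compound 3 to compound 4 (0.06 log units; within the scatter); among these four compounds, the two carrying an amine give the higher numbers and the two without one give the lower numbers, with no compound going against this. Nothing measured here accounts for the size of the gain.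

Compound 4 differs from compound 1 in both the ring and the aminomethyl group, so the compounds shown do not separate the contribution of each; an aminomethyl carried on the pyrazole ring, or a methyl in its place on the 1,2-oxazol-5-yl ring, would bear on this. Also open, from the compounds shown here alone, is how far the 1-methyl group can change, for instance to a longer chain such as propyl or to a chain ending in a carboxylic acid.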